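A few compounds are considered here, and "the series" means these few. Any claim that something is new, unique, unknown or untested is made for them only; others in the source may bear on it.

Measured so far in a functional assay on SW-620 cells (Homo sapiens) for cytotoxicity, read by MTT assay, with stated times of 4 h and 72 h, tested at 2 uM; on this read-out lower numbers stand for stronger inhibition and higher numbers for weaker inhibition:

- compound 1 `Cc1cc(Nc2ccc(C(=O)/C=C/c3ccc4ccccc4c3)cc2)n2nc(SC(=O)c3csc4ccc(Cl)cc34)nc2n1` gives 35 nM here
- compound 2 `Cc1cc(Nc2ccc(C(=O)/C=C/c3ccc4ccccc4c3)cc2)n2nc(SCc3nc4ccccc4[nH]3)nc2n1` gives 5 nM here

Of these two, compound 2 at 5 nM holds the lower number. Compound 3 `Cc1cc(Nc2ccc(C(=O)/C=C/c3ccc4ccccc4c3)cc2)n2nc(SCC(=O)c3ccccc3)nc2n1` is not yet measured and differs from compound 2 by benzoyl in place of 1H-benzimidazol-2-yl on a saturated chain carbon bound to a sulfur on the same side chain, with benzoyl in place of 1H-benzimidazol-2-yl on a saturated chain carbon bound to a sulfur. Among the measured compounds shown here, only one measured step bears on this change, a 7.0-fold lower number from compound 1 to compound 2 (0.85 log units; beyond the scatter), a modest step that also alters the group on the sulfur. Compound 1, at 35 nM on this evidence, lacks the 1H-benzimidazol-2-yl group, as compound 3 will. A loss of similar or smaller size is therefore expected in this assay, toward a higher number. The expected change is a 3.0-fold higher number from compound 2 to compound 3 (0.48 log units; beyond the scatter) in this assay. Compound 3 is estimated at 15 nM, with 4 nM to 60 nM as the expected range.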

Compound 3, half-maximal inhibitory concentration: 190 nM
The estimate for compound 3 lay 13-fold (1.10 log units) below the measured number; the measured number lies above the stated range.
By their numbers in this assay, from the lowest: compound 2; then compound 1; then compound 3.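

In this assay, among the compounds shown here, the group on a saturated chain carbon bound to a sulfur matters more than the one earlier step could show: benzoyl in place of 1H-benzimidazol-2-yl gives a 38-fold higher number from compound 2 to compound 3 (1.58 log units; beyond the scatter) and is a large step. Compounds without the 1H-benzimidazol-2-yl group also differ among themselves, since benzoylmethyl in place of (5-chloro-1-benzothiophen-3-yl)carbonyl on a sulfur gives a 5.4-fold higher number from compound 1 to compound 3 (0.73 log units; beyond the scatter) and so the group on the sulfur still shifts the number once 1H-benzimidazol-2-yl is gone. No measurement at hand accounts for either step.

Benzoyl differs from 1H-benzimidazol-2-yl in ring count, hetero atoms and hydrogen-bond donors at once, so these compounds do not show which of these differences goes with the step. A benzoxazol-2-yl group, which keeps both rings but has no ring nitrogen-bound hydrogen, would separate them on the same carbon.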